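The compounds below may be only part of what the source reports. "The series", "measured", "known", "first", "only" and "open" are said of these compounds alone.

Of the compounds shown here, three have been tested in an ADME assay on cells (Homo sapiens) for cytotoxicity, read by resazurin assay, with a stated time of 5 days; on this read-out higher numbers stand for lower toxicity in this test and lower numbers for higher toxicity in this test. Compound 1, `O=S(=O)(Cc1nc(-c2cccs2)c2sccc2n1)c1cccc(Cl)c1`, gives > 50000 nM in this assay, which is a limit of the assay rather than a number. Compound 2, `COc1ccc(-c2nc(COc3cccc(Cl)c3)nc3ccsc23)cn1`, likewise reaches only the limit > 50000 nM in this assay. Compound 3, `COc1ccc(-c2nc(CSc3ccc(C(F)(F)F)cn3)nc3ccsc23)cn1`, also stops at the limit > 50000 nM in this assay. So compound 2 stands exactly where every other value stands: the limit of > 50000 nM in this assay, at which 3 of the 3 values shown sit. Nothing in these numbers separates compound 2 from compound 1 or compound 3; all three simply show no measurable toxicity within the range the assay covers.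

Compound 4, `COc1ccc(-c2nc(CSc3cccc(Cl)c3)nc3ccsc23)cn1`, has not yet been measured. It differs from compound 2 in one place: (3-chlorophenyl)sulfanyl in place of 3-chlorophenoxy on a saturated chain carbon bound to an aromatic carbon. For the measured compounds named here, no pair of measured compounds differs in a single place, so no measured step shows what such a swap does in this setting.

Going by the values given here, because of the limit of > 50000 nM in this assay, at which 3 of the 3 values shown sit, the only information available is that every measured compound sits at the same limit, and compound 4 is expected to behave the same way. The step expected a number no higher from compound 2 to compound 4 (the limit leaves the size open) is none beyond the scatter. Compound 4 is therefore estimated at 50000 nM in this assay, within a range of 25000 nM to 100000 nM, and most likely it will again be reported only as a limit.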

Compound 4, half-maximal cytotoxic concentration: > 10000 nM
Compound 4: only a limit was reported; the forecaster's own chance of this, stated with the estimate: 85%; the middle value does not contradict the limit.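

Compound 2 and compound 4 are both reported in this assay only as limits, not as numbers, and the step between them, (3-chlorophenyl)sulfanyl in place of 3-chlorophenoxy, cannot be read. The compounds shown leave open at what concentration, if any, each becomes toxic to these cells, and whether this swap changes that concentration at all.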